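An extra methoxy on compound 3

The source may hold more compounds than are shown below. What is called first, only, known or untested is meant among the compounds shown, and "the series" means these compounds.

Compound 1 `COc1ccc(/C=C2\CCC/C(=C\c3ccc(Cl)cc3)C2=O)cc1OC` gives 5900 nM
Compound 2 `COc1ccccc1/C=C1\CCC/C(=C\c2ccc(OC)c(OC)c2)C1=O` gives 7800 nM
Compound 3 `COc1cccc(/C=C2\CCC/C(=C\c3ccc(OC)c(OC)c3)C2=O)c1` gives 3700 nM

In a functional assay on SW-620 cells (Homo sapiens) for cytotoxicity, read by MTT assay, with a stated time of 72 h (on this read-out higher numbers stand for weaker inhibition and lower numbers for stronger inhibition), compound 3 sits at the low end of these numbers, with a 1.6-fold lower number from compound 1 to compound 3 (0.20 log units; within the scatter) and a 2.1-fold lower number from compound 2 to compound 3 (0.32 log units; beyond the scatter). Compound 4 `COc1cc(/C=C2\CCC/C(=C\c3ccc(OC)c(OC)c3)C2=O)cc(OC)c1` differs from it by methoxy in place of hydrogen on an aromatic carbon, meta to a large group and meta to a methoxy group. Among the compounds with values here, no measured step adds a group in this way. The closest guides are swaps of one substituted phenyl for another, which gave a 1.3-fold higher number from compound 1 to compound 2 (0.12 log units; within the scatter) and, as the largest, the modest 2.1-fold lower number from compound 2 to compound 3 (0.32 log units; beyond the scatter). These steps do not settle a direction, so only a small change is expected in this assay. The expected outcome is a 1.1-fold lower number from compound 3 to compound 4 (0.02 log units; within the scatter). For compound 4 the estimate is 3500 nM, with an expected range from 1500 nM to 8000 nM.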

Compound 4, half-maximal inhibitory concentration: 2500 nM
Estimate against measurement, compound 4: 1.4-fold (0.15 log units) above; low and high end bracket the measured number.
By their numbers in this assay, from the lowest: compounds 4, 3, 1 and 2 (each within the scatter of the next, the first and the last beyond it).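

Putting methoxy in place of hydrogen on this aromatic carbon, meta to a large group and meta to a methoxy group, gives a 1.5-fold lower number from compound 3 to compound 4 (0.17 log units; within the scatter) in this assay. This is the only step shown that adds a group to the ring instead of swapping one substituted phenyl for another, and it shows that this position takes a methoxy with no clear gain or loss.

As far as these compounds go, whether an amine, a carboxylic acid or a longer chain at the same position would also leave the number unchanged stays open. Nothing measured here offers a reason for this result.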